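Hydroxy for dimethylamino on a sulfonyl sulfur

A few compounds are considered here, and "the series" means these few. Any claim that something is new, unique, unknown or untested is made for them only; others in the source may bear on it.

Measured in a functional assay on the whole organism with Rattus norvegicus as the target; a lower number here means that less compound is needed, a higher number that more compound is needed for the effect:
- Compound 1 `N=c1sc2cc(OC(F)(F)F)ccc2n1CC(=O)O`: > 10 mg/kg (a limit)
- Compound 2 `CN(C)S(=O)(=O)CCn1c(=N)sc2cc(OC(F)(F)F)ccc21`: > 10 mg/kg (a limit)

Compound 2 stands at > 10 mg/kg, which is a limit and not a number. Compound 3 `N=c1sc2cc(OC(F)(F)F)ccc2n1CCS(=O)(=O)O` carries hydroxy in place of dimethylamino on a sulfonyl sulfur. Within the data shown here, the one measured step that bears on this change is a step that the two limits leave unreadable from compound 1 to compound 2, so it offers no size to carry over. Compound 1 and compound 2 both sit at the limit of > 10 mg/kg in this assay, at which 2 of the 2 values shown sit. No shift beyond the scatter is therefore expected in this assay, and another limit is the likeliest report. The estimated step is a step that the limit leaves unreadable from compound 2 to compound 3. Compound 3 is expected at 15 mg/kg, within an estimated range of 6 mg/kg to 40 mg/kg.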

Compound 3, dose for half-maximal effect: > 10 mg/kg
Compound 3 ended at the assay's limit (the forecaster's own chance of this, stated with the estimate: 80%); the middle value does not contradict the limit.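

No step can be read among compound 1, compound 2 and compound 3, as each gives a limit and not a number: the limit of > 10 mg/kg in this assay, at which 3 of the 3 values shown sit.

The compounds shown leave open how far each lies past that limit, and whether exchanging these groups changes the dose needed at all.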